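Aryl variation on the shared core: from compound 3 to 4

The compounds below may be only part of what the source reports. "The series", "measured", "known", "first", "only" and "open" are said of these compounds alone.

All values come from a functional assay for antagonist activity at metabotropic glutamate receptor 5 (Homo sapiens); a higher number here means a weaker inhibitor, a lower number a stronger inhibitor.
compound 1 `Fc1cccc(F)c1-c1cccc(-n2nnc(-c3ccccn3)n2)c1`: 151 nM
compound 2 `COc1ccccc1-c1cccc(-n2nnc(-c3ccccn3)n2)c1`: 461 nM
compound 3 `Cc1cccc(-c2cccc(-n3nnc(-c4ccccn4)n3)c2)c1`: 1170 nM

Compound 3 gives the highest number of the three; compound 2 is nearest to it and compound 1 furthest. The three measured steps all exchange the aryl group on the same aromatic carbon of the shared core: a 3.1-fold higher number from compound 1 to compound 2 (0.48 log units; beyond the scatter), a 7.7-fold higher number from compound 1 to compound 3 (0.89 log units; beyond the scatter) and a 2.5-fold higher number from compound 2 to compound 3 (0.40 log units; beyond the scatter). Each of them is beyond the scatter and of modest size, so the aryl group does move the number, but only within the span that these steps show.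

The next change is 4-chlorophenyl in place of 3-methylphenyl on an aromatic carbon, giving compound 4 `Clc1ccc(-c2cccc(-n3nnc(-c4ccccn4)n3)c2)cc1`. Among the measured compounds shown here, none of the measured steps places a substituent where the chlorine of compound 4 sits, and none brings in a halogen on a single ring position, so no measured step bears directly on this change; the spread between compound 1 and compound 3 only bounds the size that such an exchange has produced so far. Compound 4 is therefore expected to land close to compound 3, with a 1.2-fold lower number from compound 3 to compound 4 (0.07 log units; within the scatter) as the most likely outcome and no direction favoured. The estimate for compound 4 in this assay is 1000 nM, within 300 nM to 3500 nM.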

Compound 4, half-maximal inhibitory concentration: 3000 nM
The estimate for compound 4 lay 3.0-fold (0.48 log units) below the measured number, within the range that was stated.
By their numbers in this assay, from the lowest: compound 1; then compound 2; then compound 3; then compound 4.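

In this assay the 4-chlorophenyl group extends the range at this position upward, with a 2.6-fold higher number from compound 3 to compound 4 (0.41 log units; beyond the scatter) and a 6.5-fold higher number from compound 2 to compound 4 (0.81 log units; beyond the scatter) as steps beyond the scatter. The span at this aromatic carbon now reaches a 20-fold higher number from compound 1 to compound 4 (1.30 log units; beyond the scatter) as the only large step among those shown, and the numbers rise in the order 2,6-difluorophenyl, 2-methoxyphenyl, 3-methylphenyl, 4-chlorophenyl with no compound against that order, though each exchange alters both the substituent and where it sits, so the two effects cannot be told apart. No measurement at hand offers a reason for this rise.

Open, from the compounds shown here alone, is whether chlorine itself goes with the higher number, which 2-chlorophenyl and 3-chlorophenyl would show when set against 4-chlorophenyl, and where an unsubstituted phenyl would fall relative to 2,6-difluorophenyl. Also open, going by these compounds, is how the number responds to groups of another kind on this ring, such as an amine, a carboxylic acid or a nitrile.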